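Replacing hydroxy with chloromethyl in compound 2

The source may hold more compounds than are shown below. What is called first, only, known or untested is meant among the compounds shown, and "the series" means these compounds.

In a functional assay on KYSE-450 cells (Homo sapiens) for inhibition, read by MTT assay, with a stated time of 48 h (a higher number here means a weaker inhibitor, a lower number a stronger inhibitor), compound 1 `COc1ccc(CN(C(=O)C(C)Br)c2cc(OC)c(OC)c(OC)c2)cc1O` gives 160 nM while compound 2 `COc1ccc(CN(C(=O)CO)c2cc(OC)c(OC)c(OC)c2)cc1O` gives 370 nM as the higher of the two numbers. Compound 3 `COc1ccc(CN(C(=O)CCCl)c2cc(OC)c(OC)c(OC)c2)cc1O` differs from compound 2 through chloromethyl in place of hydroxy on a saturated chain carbon bound to a carbonyl carbon. Among the measured compounds shown here, the one measured step bearing on this is a 2.3-fold higher number from compound 1 to compound 2 (0.36 log units; beyond the scatter) and it is modest, with hydroxymethyl replacing 1-bromoethyl. Going by that step, a similarly modest move to a lower number is expected for compound 3 (a 1.9-fold lower number from compound 2 to compound 3 (0.27 log units; within the scatter)). The estimated value for compound 3 is 200 nM with an expected range from 80 nM to 500 nM in this measurement.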

Compound 3, half-maximal inhibitory concentration: 110 nM
Compound 3: the middle estimate sits 1.8-fold (0.26 log units) above what was measured; the measured number falls inside the stated range.
By their numbers in this assay, from the lowest: compounds 3 and 1 (each within the scatter of the next); then compound 2.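

In this assay, the change from hydroxy to chloromethyl on the saturated chain carbon bound to a carbonyl carbon gives a 3.4-fold lower number from compound 2 to compound 3 (0.53 log units; beyond the scatter), so this position responds to the change. The two halogen-bearing groups do not separate, with 2-chloroethyl in place of 1-bromoethyl giving a 1.5-fold lower number from compound 1 to compound 3 (0.16 log units; within the scatter). No measurement shown here accounts for the gap between these groups and hydroxymethyl.

Whether the chlorine itself matters remains open, since a plain ethyl group does not appear among these compounds. As far as these compounds go, how an amine, a carboxylic acid or a longer chain would read at this place also remains open.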